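A few compounds are considered here, and "the series" means these few. Any claim that something is new, unique, unknown or untested is made for them only; others in the source may bear on it.

Measured compounds:
compound 1, `FC(F)(F)C(F)(F)C(F)(F)C(F)(F)C(F)(F)C(F)(F)CCn1cc(COc2ccccc2-c2nc3ccccc3s2)nn1`, gives 14200 nM
compound 2, `Fc1ccc(-n2cc(COc3ccccc3-c3nc4ccccc4s3)nn2)cc1Cl`, gives 14400 nM
compound 3, `FC(F)(F)Oc1ccc(-c2cc(COc3ccccc3-c3nc4ccccc4s3)on2)cc1`, gives 19900 nM

These three compounds share a core and were tested in a functional assay on COLO 205 cells (Homo sapiens) for cytotoxicity, read by MTT assay, with a stated time of 24 h; a lower number here means a stronger inhibitor, a higher number a weaker inhibitor. Compound 2 stands in the middle of the three numbers: compound 1 sits within the scatter of it, and compound 3 also sits within the scatter, so the three values cannot be told apart with confidence. All three are weak inhibitors in this assay.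

Compound 4, `c1ccc(-n2cc(COc3ccccc3-c3nc4ccccc4s3)nn2)cc1`, has not yet been measured. It differs from compound 2 in one place: phenyl in place of 3-chloro-4-fluorophenyl on an aromatic nitrogen. For the measured compounds named here, no step between two measured compounds of this kind is available, so there is no direct guide to the size of the change.

The three measured values cluster closely around the value of compound 2, 14400 nM. The expectation for compound 4 is therefore a small change or none beyond the scatter. Compound 4 is estimated at 18000 nM, with a range from 8000 nM to 40000 nM. This estimate means a step of a 1.3-fold higher number from compound 2 to compound 4 (0.10 log units; within the scatter) that is expected to stay within the scatter.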

Compound 4, half-maximal inhibitory concentration: 16600 nM
Compound 4: the middle estimate sits 1.1-fold (0.04 log units) above what was measured; low and high end bracket the measured number.
By their numbers in this assay, from the lowest: compounds 1, 2, 4 and 3 (each within the scatter of the next).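

In this assay, for the compounds shown here, putting phenyl in place of 3-chloro-4-fluorophenyl on an aromatic nitrogen gives a 1.2-fold higher number from compound 2 to compound 4 (0.06 log units; within the scatter) and is the first direct comparison at this position. Chlorine and fluorine can be removed together from this ring without a difference that can be told from the scatter, so this pair of atoms does not set the level of activity of compound 2 in this test. Nothing available explains why the step is this small.

Going by these compounds, the two halogens leave together in this step, so what each does alone stays open. On these data alone, it is also open whether a group of another kind on this phenyl ring, such as an amine or a carboxylic acid, would give a step beyond the scatter.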